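The source may hold more compounds than are shown below. What is called first, only, known or untested is meant among the compounds shown, and "the series" means these compounds.

Measured so far in a functional assay on THP-1 cells (Homo sapiens) for inhibition, read by sulforhodamine B assay, with a stated time of 48 h, tested at 50 uM; on this read-out higher numbers stand for more inhibition of growth at the one concentration tested and lower numbers for less inhibition of growth:
- compound 1 `O=C1C(=O)N(CCCCn2cc(COc3cc(=O)oc4ccccc34)nn2)c2ccc(Br)cc21`: 63%
- compound 2 `O=C1C(=O)N(CCCCn2cc(COc3cc(=O)oc4ccccc34)nn2)c2ccc(Cl)cc21`: 71%
- compound 3 `O=C1C(=O)N(CCCn2cc(COc3cc(=O)oc4ccccc34)nn2)c2ccc(Br)cc21`: 72%

Compound 1 and compound 2 share a core and differ by chloro in place of bromo on an aromatic carbon. The step of a number 8 percentage points higher from compound 1 to compound 2 (within the scatter), so the two values in this assay lie within the usual scatter of each other and give no direction for the halogen swap on this core. Compound 3 carries a different core; the difference between the core of compound 1 and the core of compound 3 is not broken down here. Compound 3 and compound 2 give values within the scatter of each other, and so do compound 3 and compound 1.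

Compound 4 `O=C1C(=O)N(CCCn2cc(COc3cc(=O)oc4ccccc34)nn2)c2ccc(Cl)cc21` remains to be measured. It differs from compound 3 by chloro in place of bromo on an aromatic carbon, the same change as that from compound 1 to compound 2, at the same place on the ring. Since compound 3 gives 72% and the earlier step was a number 8 percentage points higher from compound 1 to compound 2 (within the scatter), a step of about a number 3 percentage points higher from compound 3 to compound 4 (within the scatter) is expected in this assay, again within the scatter. The estimate for compound 4 in this assay is 75%, expected to fall between 62% and 87%.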

Compound 4, percent growth inhibition at one concentration: 78%
Compound 4: middle estimate off by 3 percentage points, on the low side; measured number inside the range.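

On the core of compound 3, chloro in place of bromo on the aromatic carbon gives a number 6 percentage points higher from compound 3 to compound 4 (within the scatter) in this assay, so this step alone sets no direction for the swap. Set beside the earlier step, the change reads alike on both cores: the same change on two cores in this assay, a number 8 percentage points higher (within the scatter) from compound 1 to compound 2 and a number 6 percentage points higher (within the scatter) from compound 3 to compound 4, 2 percentage points apart, within the scatter of two such steps. This shows that nothing in these two pairs separates the behaviour of the swap on one core from that on the other, but it does not show that chloro gives more inhibition of growth than bromo, nor that the agreement extends beyond these two cores.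

Open is how fluoro, a methoxy group or an amine on the same aromatic carbon would read in this assay, as the compounds shown carry only bromo or chloro there. Also open, as far as these compounds go, is whether the halogen swap would read the same with a longer chain on the ring nitrogen, or with a carboxylic acid in place of the halogen.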